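Changing the group on the ring nitrogen of compound 1

This account rests on a few compounds, and the source may have more. Where it says the series, first, only, none or still open, it means among the compounds named here.

Compound 1 `Nc1scc(CN2CCN(c3cccc(Cl)c3Cl)CC2)c1C(=O)c1ccc(Cl)cc1` stands highest of the three measured compounds in a functional assay on CHO cells with adenosine receptor A1 (Homo sapiens) as the target, read by cAMP accumulation and immunoassay, with a stated time of 6 min, tested at 0.1 uM (on this read-out higher numbers stand for a weaker effect at the one concentration tested and lower numbers for a stronger effect), where compound 1 gives 3.2%. In the same assay compound 2 `Nc1scc(CN2CCN(c3ccc(Cl)cc3F)CC2)c1C(=O)c1ccc(Cl)cc1` gives -9.4%, and compound 3 `Nc1scc(CN2CCN(c3ccc([N+](=O)[O-])cc3)CC2)c1C(=O)c1ccc(Cl)cc1` gives -13%. Compound 4 `Nc1scc(CN2CCN(c3cccc(C(F)(F)F)c3)CC2)c1C(=O)c1ccc(Cl)cc1` differs from compound 1 in one place: 3-(trifluoromethyl)phenyl in place of 2,3-dichlorophenyl on an amine nitrogen in a ring. For the measured compounds named here, two measured steps bear on this change, both exchanges of the same group on compound 1: a number 12.6 percentage points lower from compound 1 to compound 2 (beyond the scatter) and a number 16.2 percentage points lower from compound 1 to compound 3 (beyond the scatter), each a modest fall beyond the scatter. A third exchange of that group is therefore expected to move the number downward by a comparable modest amount, a number 12.2 percentage points lower from compound 1 to compound 4 (beyond the scatter). Compound 4 is estimated to give -9%, with a range from -25% to 8%.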

Compound 4, a percentage reported as activity, at one concentration (the size of the read-out at that concentration, not a potency): -30%
Compound 4: the middle estimate sits 21 percentage points above what was measured; measured number outside the range, below it.
By their numbers in this assay, from the lowest: compound 4; then compounds 3 and 2 (each within the scatter of the next); then compound 1.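

In this assay, the group on this ring nitrogen proves able to move the number much further than the earlier exchanges showed, a large step (a number 33.2 percentage points lower from compound 1 to compound 4 (beyond the scatter)) where those were modest. The 3-(trifluoromethyl)phenyl group also stands apart from the other two replacements, both against 4-nitrophenyl (a number 17 percentage points lower from compound 3 to compound 4 (beyond the scatter)) and against 4-chloro-2-fluorophenyl (a number 20.6 percentage points lower from compound 2 to compound 4 (beyond the scatter)). Nothing available explains this gap.

From the compounds shown here alone, whether the step belongs to the trifluoromethyl group itself or to where it sits on the phenyl ring stays open. So does how a phenyl ring carrying a methoxy group or a nitrile would read here.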